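The source may report more compounds than this note shows. Statements on the series, on what has been measured and on what is new or still open speak of the compounds shown alone.

Among the measured compounds shown here, compound 1 `O=C1Cc2cc(S(=O)(=O)N3CCN(c4ccc(O)cc4)CC3)ccc2N1` gives 2370 nM in an assay on isolated protein for inhibition of lysosomal alpha-glucosidase (Homo sapiens), read by fluorescence, with stated times of 5 min and 45 min (on this read-out higher numbers stand for weaker inhibition and lower numbers for stronger inhibition), and holds the lower of the two numbers measured so far. Compound 2 `O=C1Cc2cc(S(=O)(=O)N3CCN(c4ccc(Cl)cc4)CC3)ccc2N1` gives 94300 nM in this assay; the step of a 40-fold higher number from compound 1 to compound 2 (1.60 log units; beyond the scatter) is the only measured one that bears on this position. Compound 3 `O=C1Cc2cc(S(=O)(=O)N3CCN(c4ccc(CO)cc4)CC3)ccc2N1` carries hydroxymethyl in place of hydroxy on an aromatic carbon. The hydroxy here is not removed but pushed out by one carbon, keeping its one hydrogen-bond donor and one hydrogen-bond acceptor, so a step in the same direction as a 40-fold higher number from compound 1 to compound 2 (1.60 log units; beyond the scatter) but smaller is expected, namely a 3.4-fold higher number from compound 1 to compound 3 (0.53 log units; beyond the scatter). For compound 3 the estimate in this assay is 8000 nM, within 2500 nM to 40000 nM.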

Compound 3, half-maximal inhibitory concentration: 13000 nM
For compound 3 the middle estimate is 1.6-fold (0.21 log units) below the measured one, and the stated range covers the measured number.
By their numbers in this assay, from the lowest: compound 1; then compound 3; then compound 2.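

In this assay the hydroxy cannot be shifted out by one carbon without loss, even though hydroxymethyl has the same donor and acceptor count (a 5.5-fold higher number from compound 1 to compound 3 (0.74 log units; beyond the scatter)). Much of the chloro loss is nonetheless recovered with hydroxymethyl (a 7.3-fold lower number from compound 2 to compound 3 (0.86 log units; beyond the scatter)). Matching counts alone therefore do not restore the level of compound 1 at this position.

Going by these compounds, it remains open how a methoxy, an amine or a longer hydroxyethyl chain would read here. The data offer no explanation for the order of these three compounds.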